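The compounds below may be only part of what the source reports. "The series", "measured", "known", "first", "only" and "open" are said of these compounds alone.

Measured so far in an ADME assay on microsomes from liver (Rattus norvegicus) for metabolic stability, read by LC-MS, tested at 0.5 uM; on this read-out higher numbers stand for a longer-lived compound and lower numbers for a shorter-lived compound:

- compound 1 `Cc1nc(C)c([C@H](OC(C)(C)C)C(=O)O)c(N2CCC(C)(C)CC2)c1-c1ccc(OCCc2ccc(F)c(F)c2)cc1`: 0.85 h
- compound 2 `Cc1ncsc1CCOc1ccc(-c2c(C)nc(C)c([C@H](OC(C)(C)C)C(=O)O)c2N2CCC(C)(C)CC2)cc1`: the read-out is a limit of the assay

In this assay compound 1 gives 0.85 h. For compound 2 the result > 2 h is a limit of the assay and not a number. Compound 2 thus sits at the upper end of the two results shown, as the limit of > 2 h in this assay, at which 1 of the 2 values shown sits, records. Going by the values given here, the one measured step, an at least 2.3-fold higher number from compound 1 to compound 2 (0.37 log units; beyond the scatter), is the only point of reference for the series.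

Compound 3 `Cc1nc(C)c(CCOc2ccc(-c3c(C)nc(C)c([C@H](OC(C)(C)C)C(=O)O)c3N3CCC(C)(C)CC3)cc2)s1` differs from compound 2 by methyl in place of hydrogen on an aromatic carbon. Among the compounds with values here, no measured step concerns a change of this kind; the step from compound 1 to compound 2 exchanged one aromatic group for another on the chain and so bears on the new change only in that it places compound 2 at the limit. The expectation for the step from compound 2 to compound 3 is therefore none beyond the scatter, a step that the limit leaves unreadable from compound 2 to compound 3, with a fair chance that compound 3 also returns only a limit. Compound 3 is expected at 2.5 h, in a range from 1.2 h to 6 h.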

Compound 3, half-life: > 2 h
Compound 3 ended at the assay's limit (the forecaster's own chance of this, stated with the estimate: 60%); the middle value does not contradict the limit.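

In this assay compound 3 gives > 2 h, which is a limit of the assay and not a number. With 2,4-dimethyl-1,3-thiazol-5-yl in place of 3,4-difluorophenyl the series shows an at least 2.3-fold higher number from compound 1 to compound 3 (0.37 log units; beyond the scatter), so the higher number first seen with 4-methyl-1,3-thiazol-5-yl persists when a methyl enters on the aromatic carbon next to the ring nitrogen and next to the ring sulfur. The step between the two compounds bearing these groups cannot be read, so this position tolerates methyl only in the sense that the result stays at the limit, which now holds for compound 2 and compound 3 alike: the limit of > 2 h in this assay, at which 2 of the 3 values shown sit.

On these data alone, whether methyl in place of hydrogen on this carbon lengthens, shortens or leaves unchanged the half-life remains open, since neither compound 2 nor compound 3 has a number to compare. Also open, as far as these compounds go, is whether a trifluoromethyl or an amine on the same ring carbon, or a longer chain between the oxygen and the five-membered ring, would keep the result at the limit or bring it back into the readable range.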